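The compounds below may be only part of what the source reports. "The series", "measured", "known", "first", "only" and "open" are said of these compounds alone.

Working notes. Compound 3 `COC(=O)N1CCC(Oc2cc(Oc3ccc(/C=C4\SC(=O)NC4=O)cc3)ncn2)CC1` gives, in a functional assay on CHO-K1 cells for agonist activity at Glucose-dependent insulinotropic receptor (Homo sapiens), read by cAMP accumulation and immunoassay, with a stated time of 1 h (a lower number here means that less compound is needed, a higher number that more compound is needed for the effect), "not active" (no number reported) and so stands on no number at all. Compound 4 `CC(C)COC(=O)N1CCC(Oc2cc(Oc3ccc(/C=C4\SC(=O)NC4=O)cc3)ncn2)CC1` differs from it by isopropyl in place of hydrogen on a saturated chain carbon bound to an oxygen next to a carbonyl group. Within the data shown here, the only measured step of this kind lies on the core of compound 1 `COC(=O)N1CCC(Oc2ncnc(Oc3ccc(/C=C4\SC(=O)NC4=O)cc3)c2C)CC1`, which gives 1410 nM, and compound 2 `Cc1c(Oc2ccc(/C=C3\SC(=O)NC3=O)cc2)ncnc1OC1CCN(C(=O)OCc2ccccc2)CC1`, which gives 805 nM: the step of a 1.8-fold lower number from compound 1 to compound 2 (0.24 log units; within the scatter) is within the scatter, so enlarging the group at the same place left this assay unchanged there. Among the measured compounds shown here, with compound 3 showing no activity and the one comparable step showing no shift, compound 4 is expected to remain weak and may again return no number. The estimate for compound 4 is 6000 nM, with a range from 1500 nM to 40000 nM.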

Compound 4, half-maximal effective concentration: 745 nM
Compound 4: middle estimate off by 8.1-fold (0.91 log units), on the high side; the whole stated range lies above it.
By their numbers in this assay, from the lowest: compounds 4, 2 and 1 (each within the scatter of the next).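

Among these compounds, compound 3 has no number in this assay, so no step to compound 4 can be read. The compounds shown leave open how far methoxycarbonyl to isobutoxycarbonyl shifts the number on this core. No measured evidence bears on this result.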